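A few compounds are considered here, and "the series" means these few. Any claim that something is new, unique, unknown or untested is made for them only; others in the source may bear on it.

Measured in an ADME assay on U2OS cells (Homo sapiens) for cytotoxicity; a higher number here means that more compound is tolerated, a lower number that less compound is tolerated:
- compound 1 `CC(C)(O)c1cc2c(-c3ccc4ccccc4c3)nccc2[nH]1`: 22500 nM
- compound 2 `Cc1cccc(-c2nccc3[nH]c(C(C)(C)O)cc23)c1`: 121000 nM
- compound 3 `CC(C)(O)c1cc2c(-c3ccc(NC(=O)OCc4ccccc4)cc3)nccc2[nH]1`: 5500 nM

Compound 2 has the highest of the three numbers, so it is the best tolerated so far. Compound 4 `CC(C)(O)c1cc2c(-c3ccccc3)nccc2[nH]1` departs from it by one small change: hydrogen in place of methyl on an aromatic carbon. Among the measured compounds shown here, no measured pair isolates this change. Compound 1 at 22500 nM and compound 3 at 5500 nM both carry larger groups than compound 2 and both sit lower, so a small rise seems more likely than a fall. The step expected is a 1.2-fold higher number from compound 2 to compound 4 (0.06 log units; within the scatter), which stays within the scatter. For compound 4 the estimated value is 140000 nM, with an expected range of 60000 nM to 350000 nM.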

Compound 4, half-maximal cytotoxic concentration: 22200 nM
The estimate for compound 4 lay 6.3-fold (0.80 log units) above the measured number; measured number outside the range, below it.
By their numbers in this assay, from the lowest: compound 3; then compounds 4 and 1 (each within the scatter of the next); then compound 2.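

In this assay, hydrogen in place of methyl on an aromatic carbon, meta to a large group, gives a 5.5-fold lower number from compound 2 to compound 4 (0.74 log units; beyond the scatter) and so shows that this single methyl carries a step beyond the scatter. Among the compounds shown here, no earlier pair isolated this position, and here the loss of the methyl goes with less compound tolerated. Nothing measured accounts for this step.

Open, going by these compounds, is whether an ethyl, a methoxy or a chlorine at this position would tolerate like the methyl or like the hydrogen. On these data alone, the effect of a methyl elsewhere on this ring also stays open.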